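The source may report more compounds than this note shows. Statements on the series, on what has been measured and on what is new or still open speak of the compounds shown alone.

Of the compounds shown here, three built on a shared core have been measured in a physicochemical assay for solubility, in phosphate buffer, at pH 7.4; on this read-out higher numbers stand for higher solubility and lower numbers for lower solubility. Compound 1, `N#Cc1cc(-c2cc(=O)[nH]c(N)n2)cc(C(F)(F)F)c1`, gives 430000 nM. Compound 2, `N#Cc1c(-c2ccc(OCC3CCOC3)c(OC(F)(F)F)c2)nc(N)[nH]c1=O`, gives 86000 nM. Compound 3, `CC(C)(C)COc1ccc(-c2cc(=O)[nH]c(N)n2)cc1`, gives 3100 nM, the lowest of the three numbers; its nearest neighbour is compound 2, which stands higher by a margin beyond the scatter, and compound 1 stands further above it still. A fourth compound, compound 4, `Nc1nc(-c2ccc(OCCCCO)cc2)cc(=O)[nH]1`, has not yet been measured in this assay. It differs from compound 3 in a single place: 3-hydroxypropyl in place of tert-butyl on a saturated chain carbon bound to an oxygen on an aromatic ring. Among the compounds with values here, no step between two measured compounds that differ in one place is available, so the step from compound 3 to compound 4 can be judged only from the change itself. Compound 4 is expected to return a higher number than compound 3, with the step of a 19-fold higher number from compound 3 to compound 4 (1.29 log units; beyond the scatter) estimated to lie beyond the scatter. For compound 4 the solubility is accordingly estimated at 60000 nM, within a range from 15000 nM to 250000 nM.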

Compound 4, solubility: 95000 nM
The estimate for compound 4 lay 1.6-fold (0.20 log units) below the measured number; low and high end bracket the measured number.
By their numbers in this assay, from the lowest: compound 3; then compounds 2 and 4 (each within the scatter of the next); then compound 1.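

Within the data shown here, until now no pair of compounds differed in one place, and this exchange of tert-butyl for 3-hydroxypropyl on a saturated chain carbon bound to an oxygen on an aromatic ring gives, in this assay, a 31-fold higher number from compound 3 to compound 4 (1.49 log units; beyond the scatter). The step is large and beyond the scatter, so the number in this assay is sensitive to what this position carries, even though the heavy-atom count stays unchanged and the entering group adds a hydrogen-bond donor and a hydrogen-bond acceptor. No measurement bears on what lies behind the step.

Going by these compounds, whether the hydroxyl or the loss of the tert-butyl branching carries the step stays open, and an unbranched butyl, a 3-methoxypropyl or a 3-aminopropyl in the same place would separate the two. On these data alone, whether the exchange gives a step of like size on other substituted versions of the shared core also stays open.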